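Dropping the Phenyl Group from Compound 3

The source may hold more compounds than are shown below. What is called first, only, known or untested is meant among the compounds shown, and "the series" means these compounds.

Going by the values given here, in a functional assay on K562 cells (Homo sapiens) for antiproliferative activity, read by MTT assay, with a stated time of 48 h (a lower number here means a stronger inhibitor, a higher number a weaker inhibitor), compound 3 (`CN(C)CCCn1nc(C2=C(c3cn(C)c4ccccc34)C(=O)N(c3ccccc3)C2=O)c2cccnc21`) gives 1700 nM as the lowest number of the three compounds measured so far. Compound 1 (`Cn1cc(C2=C(c3nn(CCCn4ccnc4)c4ncccc34)C(=O)NC2=O)c2ccccc21`) sits higher with 13800 nM and compound 2 (`CN1CCN(CCCn2nc(C3=C(c4cn(C)c5ccccc45)C(=O)NC3=O)c3cccnc32)CC1`) higher still with 46700 nM on this scale.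

Compound 4 (`CN(C)CCCn1nc(C2=C(c3cn(C)c4ccccc34)C(=O)NC2=O)c2cccnc21`) has not yet been measured. It keeps the chain of compound 3 but carries hydrogen in place of phenyl on an amide-type nitrogen in a ring. Among the compounds with values here, no measured step makes this exact change. Within the data shown here, the only measured step is a 3.4-fold higher number from compound 1 to compound 2 (0.53 log units; beyond the scatter) and it alters the group at the end of the chain, which shows that this end alone can move the number. Compound 3 also differs from compound 1 and compound 2 at that chain end, so the share of the phenyl group cannot be separated out.

Compound 1 with 13800 nM and compound 2 with 46700 nM both carry that hydrogen, so a clearly higher number is expected for compound 4 than for compound 3. The estimated step is an 8.2-fold higher number from compound 3 to compound 4 (0.92 log units; beyond the scatter) and it remains uncertain. In this assay the expected value for compound 4 is 14000 nM (estimated range 4000 nM to 45000 nM).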

Compound 4, half-maximal inhibitory concentration: 50400 nM
Compound 4: the middle estimate sits 3.6-fold (0.56 log units) below what was measured, and the stated range ends below it.
By their numbers in this assay, from the lowest: compound 3; then compound 1; then compounds 2 and 4 (each within the scatter of the next).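

In this assay, the phenyl group on the amide-type nitrogen in a ring carries a large weight, since hydrogen in its place gives the step (a 30-fold higher number from compound 3 to compound 4 (1.47 log units; beyond the scatter)), which is larger than any step seen so far at the chain end. With hydrogen on that nitrogen, the group at the chain end matters in one comparison and not in the other: dimethylamino and 4-methylpiperazin-1-yl cannot be told apart (a 1.1-fold higher number from compound 2 to compound 4 (0.03 log units; within the scatter)), whereas dimethylamino in place of 1H-imidazol-1-yl gives a modest step beyond the scatter (a 3.7-fold higher number from compound 1 to compound 4 (0.56 log units; beyond the scatter)). Nothing measured here accounts for the size of the phenyl step, so the numbers record what the change does but give no reason for it.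

Phenyl was read only on compound 3, with its dimethylamino chain end, so it remains open whether phenyl would bring a similar change with 1H-imidazol-1-yl or 4-methylpiperazin-1-yl at the chain end. Only phenyl and hydrogen appear on this nitrogen, which also leaves open what a methyl, a benzyl or a 4-chlorophenyl group would give there.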